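A few compounds are considered here, and "the series" means these few. Any claim that something is new, unique, unknown or untested is made for them only; others in the source may bear on it.

Three compounds have been followed in an ADME assay on a cell-free system (serum) for metabolic stability; a higher number here means that the compound lasts longer, a lower number that the compound disappears faster. Compound 1 `CC(C)(C)c1cc(OC(=O)c2c(Cl)cc(N)cc2Cl)ccc1O` gives < 0.25 h, which is a limit of the assay and not a number. Compound 2 `CNc1cc(Cl)c(C(=O)Nc2ccc(O)c(C(C)(C)C)c2)c(Cl)c1` gives > 1 h, again a limit. Compound 3 `CN(C)c1cc(Cl)c(C(=O)N(C)c2ccc(O)c(C(C)(C)C)c2)c(Cl)c1` gives > 1 h, also a limit, so no exact half-life is known for it and it shares its place with compound 2.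

Compound 4 `CN(C)c1cc(Cl)c(C(=O)N(Cc2cccnc2)c2ccc(O)c(C(C)(C)C)c2)c(Cl)c1` is built from compound 3 by one change: pyridin-3-yl in place of hydrogen on a saturated chain carbon bound to an amide-type nitrogen. In words, pyridin-3-yl takes the place of hydrogen on a saturated chain carbon bound to an amide-type nitrogen, turning methyl into (pyridin-3-yl)methyl.

Among the measured compounds shown here, no measured pair shows what such a change does in this assay. The expectation therefore rests on compound 3 at > 1 h, a limit, and compound 4 keeps its amide-type nitrogen. The estimated step that the limit leaves unreadable from compound 3 to compound 4 is expected to stay within the scatter, with no clear direction. Another report as a limit is likely. For compound 4 the expected half-life is 1.5 h, within an estimated range of 0.6 h to 4 h.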

Compound 4, half-life: > 1 h
Compound 4: only a limit was reported (the forecaster's own chance of this, stated with the estimate: 65%); the middle value does not contradict the limit.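

In this assay compound 4 gives > 1 h, which is a limit and not a number. Among the compounds shown here, compound 3 also stands at a limit, so no step between compound 3 and compound 4 can be read. The compounds shown leave open how long compound 2, compound 3 and compound 4 actually last, and whether pyridin-3-yl in place of hydrogen changes the half-life at all: the limit of > 1 h in this assay, at which 3 of the 4 values shown sit.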